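The compounds below may be only part of what the source reports. "The series", "measured", "known", "first", "only" and "open" are said of these compounds alone.

Measured so far:
Compound 1, `COc1ccc(C(=O)/C=C/c2cc(-c3cc(OC)c(OC)c(OC)c3)n[nH]2)cc1OC`, gives 1320 nM in a functional assay on OVCAR-8 cells (Homo sapiens) for inhibition, read by sulforhodamine B assay, with a stated time of 48 h; a higher number here means a weaker inhibitor of growth, a lower number a stronger inhibitor of growth.
Compound 2, `COc1cc(-c2cc(/C=C/C(=O)c3ccc(F)c(F)c3)[nH]n2)cc(OC)c1OC`, gives 2880 nM in this assay.

Among the measured compounds shown here, compound 1 holds the lower of the two numbers; the only measured step is a 2.2-fold higher number from compound 1 to compound 2 (0.34 log units; beyond the scatter), which exchanges the group on the carbonyl carbon. Compound 3, `COc1cc(C(=O)/C=C/c2cc(-c3cc(OC)c(OC)c(OC)c3)n[nH]2)cc(OC)c1OC`, keeps that group and instead differs from compound 1 by methoxy in place of hydrogen on an aromatic carbon. No measured step touches a change of this kind, so nothing shown speaks for a shift in either direction, and a step within the scatter, a 1.2-fold lower number from compound 1 to compound 3 (0.08 log units; within the scatter), is expected. Compound 3 is therefore estimated at 1100 nM, with a range from 300 nM to 4000 nM.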

Compound 3, concentration for 50% growth inhibition: 1580 nM
Estimate against measurement, compound 3: 1.4-fold (0.16 log units) below; the range from low to high includes it.
By their numbers in this assay, from the lowest: compounds 1, 3 and 2 (each within the scatter of the next, the first and the last beyond it).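

Placing methoxy in place of hydrogen on an aromatic carbon, ortho to a methoxy group, is a step of a 1.2-fold higher number from compound 1 to compound 3 (0.08 log units; within the scatter) in this assay and so leaves growth inhibition unchanged as far as this measurement can tell. Unlike the earlier step, which exchanged the whole group on the carbonyl carbon, this one shows that the ring tolerates a methoxy group at this position. No measurement shown explains this result. Going by these compounds, whether a hydroxyl group, an amine or a longer chain such as ethoxy would be tolerated here remains open.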